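Swapping the Amide Substituent: Cyclopentyl to Benzylidene-Amino

The compounds below may be only part of what the source reports. "The series", "measured", "known", "first", "only" and "open" are said of these compounds alone.

Compound 2 `Nc1c(C(=O)NC2CCCC2)oc2nc(-c3ccccc3)cc(C(F)(F)F)c12` was tested in an ADME assay on HEK293 cells (Homo sapiens) for antiproliferative activity, read by MTT assay (on this read-out lower numbers stand for stronger inhibition and higher numbers for weaker inhibition), where compound 2 gives 85000 nM. Of the two numbers recorded so far, compound 2 has the higher one; its nearest neighbour is compound 1 `CCNC(=O)c1oc2nc(-c3ccccc3)cc(C(F)(F)F)c2c1N`, which in this assay gives 70000 nM. The two differ only at the amide-type nitrogen, and the step from compound 1 to compound 2 is a 1.2-fold higher number from compound 1 to compound 2 (0.08 log units; within the scatter), so replacing ethyl with cyclopentyl there left the read-out essentially where it was.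

Compound 3 `Nc1c(C(=O)N/N=C/c2ccccc2)oc2nc(-c3ccccc3)cc(C(F)(F)F)c12` has not yet been measured. It carries a group of 8 heavy atoms (7 carbon, 1 nitrogen; one six-membered aromatic ring of carbon only) in place of a group of 5 heavy atoms (5 carbon; one five-membered non-aromatic ring of carbon only), on an amide-type nitrogen; the entering group brings one double bond outside aromatic rings and one hydrogen-bond acceptor. For the measured compounds named here, the only measured step touching this position is the one from compound 1 to compound 2, which stayed within the scatter, so a further change of the group on the amide-type nitrogen is expected to shift this assay little, with no clear direction. In this assay the expected step comes out as a 1.3-fold lower number from compound 2 to compound 3 (0.12 log units; within the scatter). Compound 3 is estimated at 65000 nM, between 20000 nM and 200000 nM, with some chance that only a limit is reported.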

Compound 3, half-maximal inhibitory concentration: 70000 nM
Estimate against measurement, compound 3: 1.1-fold (0.03 log units) below; measured number inside the range.
By their numbers in this assay, from the lowest: compounds 1, 3 and 2 (each within the scatter of the next).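

In this assay the group on the amide-type nitrogen now comes in three forms, and the read-out does not separate them: one new step is a 1.2-fold lower number from compound 2 to compound 3 (0.08 log units; within the scatter) and the other is no change at the digits printed from compound 1 to compound 3 (within the scatter). The earlier pair compared only ethyl and cyclopentyl, two groups made of carbon alone, whereas the group in compound 3 brings a six-membered aromatic ring, a double bond outside aromatic rings and a hydrogen-bond acceptor, and its number still lies within the scatter of both others. So, across these three compounds, this much variety at this position gives no measurable difference, and no supporting measurement is available to explain the result.

Still open, as far as these compounds go, is whether a chain ending in an amine or a carboxylic acid on the amide-type nitrogen would move the number in this assay beyond the scatter. Also open, from the compounds shown here alone, is what a change elsewhere on the shared core would do, such as methyl in place of trifluoromethyl, since all three compounds carry the same core.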